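Predicting Compound 4 from Three Measured Analogues

The source may report more compounds than this note shows. Statements on the series, on what has been measured and on what is new or still open speak of the compounds shown alone.

Measured so far in a functional assay on B16 cells (Mus musculus) for cytotoxicity, read by MTT assay, with a stated time of 72 h; on this read-out lower numbers stand for stronger inhibition and higher numbers for weaker inhibition:
compound 1 `COc1ccc(C(=O)c2cc(OC)c(OC)c(OC)c2)cc1NC(=O)/C=C/c1cc(OC)c(OC)c(OC)c1`: compound 1 gives 1200 nM
compound 2 `COc1ccc(/C=C/C(=O)Nc2cc(C(=O)c3cc(OC)c(OC)c(OC)c3)ccc2OC)cc1`: compound 2 gives 8700 nM
compound 3 `COc1cc(C(=O)c2cc(OC)c(OC)c(OC)c2)cc(NC(=O)/C=C/c2cc(OC)c(OC)c(OC)c2)c1OC`: compound 3 gives 2500 nM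

Compound 3 stands second highest of the three numbers in this assay, beyond the scatter from both compound 1 and compound 2. Compound 4 `COc1ccc(/C=C/C(=O)Nc2cc(C(=O)c3cc(OC)c(OC)c(OC)c3)cc(OC)c2OC)cc1` differs from compound 3 by one change: 4-methoxyphenyl in place of 3,4,5-trimethoxyphenyl on a double-bonded chain carbon bound to a double-bonded chain carbon. The same change has been measured once, as a 7.3-fold higher number from compound 1 to compound 2 (0.86 log units; beyond the scatter), a weakening beyond the scatter. The other step, a 2.1-fold higher number from compound 1 to compound 3 (0.32 log units; beyond the scatter), concerns a different site and bears only indirectly. Compound 4 is therefore expected to show a weakening step of a 7.2-fold higher number from compound 3 to compound 4 (0.86 log units; beyond the scatter) in this assay. The estimate for compound 4 is 18000 nM, with a range from 7000 nM to 45000 nM.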

Compound 4, half-maximal inhibitory concentration: 9400 nM
Compound 4: middle estimate off by 1.9-fold (0.28 log units), on the high side; the range from low to high includes it.
By their numbers in this assay, from the lowest: compound 1; then compound 3; then compounds 2 and 4 (each within the scatter of the next).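

In this assay, the change to 4-methoxyphenyl gives a 3.8-fold higher number from compound 3 to compound 4 (0.58 log units; beyond the scatter), so the weakening now holds on a second core and no longer rests on one pair. Its size also carries over, as far as two pairs can show: the same change on two cores in this assay, a 7.3-fold higher number (0.86 log units; beyond the scatter) from compound 1 to compound 2 and a 3.8-fold higher number (0.58 log units; beyond the scatter) from compound 3 to compound 4, 1.9-fold (0.29 log units) apart, within the scatter of two such steps. Adding methoxy on an aromatic carbon gives a 1.1-fold higher number from compound 2 to compound 4 (0.03 log units; within the scatter), so the earlier step for this addition does not reappear beyond the scatter on the core with 4-methoxyphenyl, yet the two steps do not clearly disagree: the same change on two cores in this assay, a 2.1-fold higher number (0.32 log units; beyond the scatter) from compound 1 to compound 3 and a 1.1-fold higher number (0.03 log units; within the scatter) from compound 2 to compound 4, 1.9-fold (0.29 log units) apart, within the scatter of two such steps.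

The compounds shown leave open how a phenyl group carrying an amine or a carboxylic acid in place of the methoxy of 4-methoxyphenyl would read at this place.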